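Trifluoromethyl on the benzyl of an M5 modulator

The source may report more compounds than this note shows. Statements on the series, on what has been measured and on what is new or still open speak of the compounds shown alone.

The study centres on a shared core in which an ethyl-benzyl amide is linked to a piperidine bearing an arylsulfonyl group. Compound 1, `CCN(Cc1ccccc1)C(=O)C1CCN(S(=O)(=O)c2ccccn2)CC1`, carries the simplest sulfonyl partner, and in a functional assay on CHO cells for positive allosteric modulation of muscarinic acetylcholine receptor M5 (Homo sapiens), read by calcium flux (on this read-out lower numbers stand for smaller maximal responses and higher numbers for larger maximal responses), compound 1 gives "not determined" (no result reported), so no result is reported for it. Compound 2, `CCN(Cc1ccccc1)C(=O)C1CCN(S(=O)(=O)c2ccc3[nH]ncc3c2)CC1`, is the only member with a number: in this assay compound 2 gives 86%, and with compound 1 lacking a value, compound 2 stands alone on the numbers shown.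

Compound 3, `CCN(Cc1ccccc1C(F)(F)F)C(=O)C1CCN(S(=O)(=O)c2ccc3[nH]ncc3c2)CC1`, keeps the core and sulfonyl partner of compound 2 and differs in one place: trifluoromethyl in place of hydrogen on an aromatic carbon, that is, benzyl to 2-(trifluoromethyl)benzyl. Among the measured compounds shown here, no step between two measured compounds is available, so the size of the effect of this change is not anchored by earlier data. The trifluoromethyl group enters without ring, donors or acceptors, and the maximal response of compound 2 already lies high. Compound 3 is therefore expected to remain within the scatter of compound 2, with the step of a number 6 percentage points lower from compound 2 to compound 3 (within the scatter) estimated as small or none. Compound 3 is estimated to reach 80%, between 55% and 100%.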

Compound 3, largest response reached (reported as percent of maximum), in percent of the reference or control that the assay uses: 96%
Beside the measured number, compound 3's estimate is 16 percentage points below it; the measured number falls inside the stated range.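

In this assay, trifluoromethyl in place of hydrogen on an aromatic carbon, ortho to a large group, gives a number 10 percentage points higher from compound 2 to compound 3 (within the scatter). Among the compounds shown here, this is the only step that can be read, and it shows that this place on the benzyl accepts a group of 4 heavy atoms while the maximal response stays within the scatter of that of compound 2, so a change from benzyl to 2-(trifluoromethyl)benzyl leaves this read-out without a distinguishable shift. No measurement on hand speaks to why the response holds at this place.

The compounds shown leave open whether the same holds for other groups at this place, such as a methyl group, a chlorine atom, an amine or a carboxylic acid, and whether any of them would move the response beyond the scatter. With compound 1 at "not determined" (no result reported), they also leave open how the sulfonyl partner bears on the response, and a maximal response alone does not tell how much of either compound is needed to reach it.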